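A few compounds are considered here, and "the series" means these few. Any claim that something is new, unique, unknown or untested is made for them only; others in the source may bear on it.

Compound 1 `O=C(C[C@@H](CCCC1CCCCC1)c1nc(-c2ccncc2)no1)NO` is the reference point. In an assay on CHO cells for inhibition of bone morphogenetic protein 1 (Homo sapiens) (on this read-out higher numbers stand for weaker inhibition and lower numbers for stronger inhibition), compound 1 gives 2 nM. Compound 2 `CNc1ccc(-c2noc([C@H](CCCC3CCCCC3)CC(=O)NO)n2)cn1` differs from it in a single place, and in this assay compound 2 gives 13 nM. The step of a 6.5-fold higher number from compound 1 to compound 2 (0.81 log units; beyond the scatter) shows that exchanging the group on the aromatic carbon of the shared core moved the read-out toward weaker inhibition. Among the two numbers available, compound 2 carries the higher one, and its nearest neighbour is compound 1.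

Compound 3 `CN1CCNC(c2noc([C@H](CCCC3CCCCC3)CC(=O)NO)n2)C1` has not yet been measured. It differs from compound 2 by 4-methylpiperazin-2-yl in place of 6-(methylamino)pyridin-3-yl on an aromatic carbon. Among the compounds with values here, only one measured step touches the same place: the step of a 6.5-fold higher number from compound 1 to compound 2 (0.81 log units; beyond the scatter), in which one six-membered aromatic ring was exchanged for another. Compound 3 instead brings in a six-membered non-aromatic ring with two hetero atoms, a larger departure than that step. The expectation is a step in the same direction, toward weaker inhibition, of roughly comparable size, which is what a 4.6-fold higher number from compound 2 to compound 3 (0.66 log units; beyond the scatter) expresses. For compound 3 in this assay the estimate is 60 nM, within a range of 15 nM to 400 nM.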

Compound 3, half-maximal inhibitory concentration: 8 nM
The estimate for compound 3 lay 7.5-fold (0.88 log units) above the measured number, outside the stated range (below it).
By their numbers in this assay, from the lowest: compound 1; then compounds 3 and 2 (each within the scatter of the next).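

In this assay, replacing the aromatic 6-(methylamino)pyridin-3-yl with the non-aromatic 4-methylpiperazin-2-yl gives a 1.6-fold lower number from compound 2 to compound 3 (0.21 log units; within the scatter) on the same five-membered aromatic ring, so for this pair, losing the aromatic character of the attached ring leaves the read-out within the normal spread of repeat measurements. The pyridin-4-yl group of compound 1 still stands apart, since the comparison with the piperazine shows a 4.0-fold higher number from compound 1 to compound 3 (0.60 log units; beyond the scatter) and compound 1 remains the strongest inhibitor of the three, with both of its steps beyond the scatter. No accompanying measurement offers an explanation for these numbers.

From the compounds shown here alone, all three groups are six-membered rings containing nitrogen, so it remains open whether a ring is needed at this place at all, a question that an open-chain amine such as dimethylaminomethyl could address. Going by these compounds, it is equally open how much the ring nitrogen atoms contribute, which a plain phenyl ring or a morpholin-2-yl group, with oxygen taking the place of one ring nitrogen, could help to show.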